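Cyclohexyl to Pyrazinylmethyl on the Carbonyl-Linked Oxygen

The compounds below may be only part of what the source reports. "The series", "measured", "known", "first", "only" and "open" are said of these compounds alone.

Going by the values given here, in an assay on HEK293 cells for inhibition of neurogenic locus notch homolog protein 1 (Homo sapiens), read by a luciferase reporter and resazurin assay, with a stated time of 16 h (on this read-out higher numbers stand for weaker inhibition and lower numbers for stronger inhibition), compound 2 `CC1=C(C(=O)OC2CCCCC2)C(c2cccc(Br)c2)C2=C(CC(C)(C)CC2=O)N1` gives 4150 nM, the lowest of the two numbers measured so far. Compound 1 `CC1=C(C(=O)OC2CCCCC2)C(c2cccc(C#N)c2)C2=C(CC(C)(C)CC2=O)N1` gives 43200 nM in this assay, and a 10-fold lower number from compound 1 to compound 2 (1.02 log units; beyond the scatter) separates the two. Compound 3 `CC1=C(C(=O)OCc2cnccn2)C(c2cccc(Br)c2)C2=C(CC(C)(C)CC2=O)N1` differs from compound 2 by (pyrazin-2-yl)methyl in place of cyclohexyl on an oxygen next to a carbonyl group. Among the compounds with values here, the only step measured, a 10-fold lower number from compound 1 to compound 2 (1.02 log units; beyond the scatter), concerns a substituent on an aromatic carbon and does not bear on the oxygen next to the carbonyl group, so the data offer no guide for this change. The step of a 1.4-fold higher number from compound 2 to compound 3 (0.16 log units; within the scatter) is therefore expected to stay within the scatter. Compound 3 is estimated at 6000 nM, within 1500 nM to 25000 nM.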

Compound 3, half-maximal inhibitory concentration: 860 nM
Compound 3: the middle estimate sits 7.0-fold (0.84 log units) above what was measured, and the stated range ends above it.
By their numbers in this assay, from the lowest: compound 3; then compound 2; then compound 1.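

In this assay, going by these compounds alone, (pyrazin-2-yl)methyl in place of cyclohexyl gives a 4.8-fold lower number from compound 2 to compound 3 (0.68 log units; beyond the scatter) on an oxygen next to a carbonyl group, a position the earlier compounds left unchanged, so this site also moves the number beyond the scatter. The entering group brings an aromatic ring and 2 hydrogen-bond acceptors where cyclohexyl has none, but a single step cannot separate these features. No measurement offered here explains the step. Going by these compounds, whether a benzyl group or a (pyridin-2-yl)methyl group would give a similar number remains open. So does whether this exchange would have a similar effect with the nitrile of compound 1 in place of the bromo group.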